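Dibenzylhydrazone series: methoxy removal from compound 3

The compounds below may be only part of what the source reports. "The series", "measured", "known", "first", "only" and "open" are said of these compounds alone.

Three dibenzylhydrazones have been measured in an assay on liver (Sus scrofa) for inhibition of glucose-6-phosphatase catalytic subunit 1 (Homo sapiens), using microsomes; a lower number here means a stronger inhibitor, a higher number a weaker inhibitor. Compound 1 `C(=N/N(Cc1ccccc1)Cc1ccccc1)\c1ccccc1` gives 1500 nM, and compound 2 `C/C(=N\N(Cc1ccccc1)Cc1ccccc1)c1ccccc1` gives 25000 nM. Compound 3 `COc1ccc2c(c1)CCC/C2=N\N(Cc1ccccc1)Cc1ccccc1` gives > 50000 nM in this assay, which is a limit of the assay and not a number. Going by the values given here, compound 3 therefore stands at the edge of what this assay reports, as noted in the limit of > 50000 nM in this assay, at which 1 of the 3 values shown sits; no step between measured compounds can be drawn from it.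

Compound 4 `c1ccc(CN(Cc2ccccc2)/N=C2\CCCc3ccccc32)cc1` has not been measured. It differs from compound 3 by hydrogen in place of methoxy on an aromatic carbon, a hydrogen in place of methoxy on an aromatic carbon. Among the compounds with values here, with compound 3 known only as a limit, no measured step bears on this change, and the expectation is that the step of an at least 1.2-fold lower number from compound 3 to compound 4 (0.09 log units; that floor lies within the scatter) lies within the scatter, with no clear direction. Compound 4 is accordingly expected to sit near 40000 nM in this assay, within a range from 8000 nM to 200000 nM, with a fair chance that only a limit is returned.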

Compound 4, half-maximal inhibitory concentration: 25000 nM
Compound 4: the middle estimate sits 1.6-fold (0.20 log units) above what was measured, and the stated range covers the measured number.
By their numbers in this assay, from the lowest: compound 1; then compounds 2 and 4 (each within the scatter of the next). At a limit, above all of these: compound 3.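

In this assay, hydrogen in place of methoxy on this aromatic carbon gives an at least 2.0-fold lower number from compound 3 to compound 4 (0.30 log units; that floor lies within the scatter). Compound 3 gives > 50000 nM, which is a limit of the assay and not a number. Compound 4 therefore provides the first number at this position, but the size of the change remains only a floor that lies within the scatter, because one end of the step is a limit: the limit of > 50000 nM in this assay, at which 1 of the 4 values shown sits.

From the compounds shown here alone, whether the full step lies beyond the scatter remains open. Also open, going by these compounds, is whether the methoxy group is a special case, or whether a fluorine, a hydroxyl or an amine on the same aromatic carbon would give a number close to that of compound 4 in this assay.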